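Lengthening a Side Chain by One Carbon

This account rests on a few compounds, and the source may have more. Where it says the series, first, only, none or still open, it means among the compounds named here.

Measured in an ADME assay for lipophilicity; on this read-out lower numbers stand for lower lipophilicity and higher numbers for higher lipophilicity:
- compound 1, `CCCOCc1cc(=O)c(O)co1`: 0.3
- compound 2, `CCCCOCc1cc(=O)c(O)co1`: 0.78
- compound 3, `CCc1oc(C)cc(=O)c1O`: 1.07

Compound 1 and compound 2 share one core and differ in a single place: methyl in place of hydrogen on a saturated chain carbon, three bonds along the chain from an oxygen on a saturated carbon. In this assay this gave a number 0.48 log units higher from compound 1 to compound 2 (beyond the scatter). Compound 3 is built on a different core, and the difference between the two cores is not broken down here. Its value lies within the usual scatter of the value of compound 2, so the two cannot be told apart, while it lies beyond the scatter above the value of compound 1.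

Compound 4, `CCCc1oc(C)cc(=O)c1O`, is not yet measured. It differs from compound 3 by methyl in place of hydrogen on a saturated chain carbon, two bonds along the chain from an aromatic carbon. For the measured compounds named here, this is the same kind of change as the one from compound 1 to compound 2, but its surroundings differ: there the added methyl sat three bonds along the chain from an oxygen on a saturated carbon, here it sits two bonds along the chain from an aromatic carbon. Because a number 0.48 log units higher from compound 1 to compound 2 (beyond the scatter), a step of about the same size is expected for compound 4, namely a number 0.48 log units higher from compound 3 to compound 4 (beyond the scatter). Compound 4 is therefore estimated at 1.55, with a likely range from 1.2 to 1.95.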

Compound 4, distribution coefficient: 1.4
The estimate for compound 4 lay 0.15 log units above the measured number; measured number inside the range.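

In this assay, the methyl that turns the ethyl chain of compound 3 into the propyl chain of compound 4 gave a number 0.33 log units higher from compound 3 to compound 4 (beyond the scatter), so the step again goes upward and again lies beyond the scatter. Set beside the earlier step on the other core, the size of this step cannot be told apart from it: the same change on two cores in this assay, a number 0.48 log units higher (beyond the scatter) from compound 1 to compound 2 and a number 0.33 log units higher (beyond the scatter) from compound 3 to compound 4, 0.15 log units apart, within the scatter of two such steps This shows that, for these two pairs, the one-carbon lengthening carried over from one core to the other in both direction and approximate size, but two pairs are a small sample, and they do not show that the step would hold on any other core, at any other place on a chain, or for every chain length.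

The compounds shown leave open whether the rise continues when the chain on the core of compound 3 grows beyond propyl, since a longer chain might give a similar step, a smaller one or a larger one. They also leave open how this assay would respond if an amine or a carboxylic acid stood in place of the added methyl. Each of the two steps shown adds only that one group.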